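Half-life of a Fused-Ring Series: From Cyclopropyl to Cyclopropylmethoxy

The source may report more compounds than this note shows. Statements on the series, on what has been measured and on what is new or still open speak of the compounds shown alone.

Measured compounds:
compound 1 `CN1Cc2cc(ccc2S(=O)(=O)C2CC2)NC(=O)N(CC2CC2)CCc2cccc(c2)C(Nc2ccc3c(N)ncc(F)c3c2)C1=O`, 0.2 h
compound 2 `CN1CCc2cccc(c2)[C@@H](Nc2ccc3c(N)ncc(F)c3c2)C(=O)N(C)Cc2cc(ccc2S(=O)(=O)C2CC2)NC1=O`, 0.1 h
compound 3 `CN1Cc2cc(ccc2S(=O)(=O)C2CC2)NC(=O)CCc2cc(ccc2C2CC2)[C@@H](Nc2ccc3c(N)ncc(F)c3c2)C1=O`, 0.0833 h

In an ADME assay on liver (Rattus norvegicus) for metabolic stability, using microsomes (on this read-out lower numbers stand for a shorter-lived compound and higher numbers for a longer-lived compound), compound 1 gives 0.2 h, compound 2 gives 0.1 h and compound 3 gives 0.0833 h. Compound 3 has the lowest number of the three, but its value and that of compound 2 lie within the usual scatter of each other, so no order between them can be claimed; only compound 1 sits beyond the scatter, with a higher number.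

Compound 4 `CN1Cc2cc(ccc2S(=O)(=O)C2CC2)NC(=O)CCc2cc(ccc2OCC2CC2)[C@@H](Nc2ccc3c(N)ncc(F)c3c2)C1=O` differs from compound 3 in one place: cyclopropylmethoxy in place of cyclopropyl on an aromatic carbon. No comparable exchange has been measured in this series, so the step from compound 3 to compound 4 in this assay is expected to be small, with no clear direction beyond the scatter. Compound 4 is therefore estimated to give 0.1 h, within a range from 0.04 h to 0.3 h, which corresponds to an expected step of a 1.2-fold higher number from compound 3 to compound 4 (0.08 log units; within the scatter).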

Compound 4, half-life: 0.383 h
The estimate for compound 4 lay 3.8-fold (0.58 log units) below the measured number; the measured number lies above the stated range.
By their numbers in this assay, from the lowest: compounds 3, 2, 1 and 4 (each within the scatter of the next, the first and the last beyond it).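

In this assay, putting cyclopropylmethoxy in place of cyclopropyl on this aromatic carbon gives a 4.6-fold higher number from compound 3 to compound 4 (0.66 log units; beyond the scatter), the only one-place comparison among the compounds shown. It shows that this position can alter the half-life beyond the scatter, even though both groups carry the same three-membered carbon ring. Nothing available explains why the half-life differs.

On these data alone, whether the oxygen link or the greater length of the group matters remains open. A methoxy group, a longer ether chain or an amine on this carbon could help separate the two.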